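From Chloro to Bromo: Expecting No Shift Beyond Scatter

The source may report more compounds than this note shows. Statements on the series, on what has been measured and on what is new or still open speak of the compounds shown alone.

Two measured compounds frame the question. Compound 1 `Fc1ccc(-c2cc(OC[C@@H]3CCN3)cnc2Cl)cn1` carries a fluoro group, and in an assay on membranes from brain with Neuronal acetylcholine receptor; alpha4/beta2 (Rattus norvegicus) as the target (a lower number here means a stronger inhibitor, a higher number a weaker inhibitor), compound 1 gives 0.0049 nM. Compound 2 `Clc1ccc(-c2cc(OC[C@@H]3CCN3)cnc2Cl)cn1` carries a chloro group in its place, and in this assay compound 2 gives 0.0045 nM. Within the data shown here, the only measured step, a 1.1-fold lower number from compound 1 to compound 2 (0.04 log units; within the scatter), shows that these two values cannot be told apart, so compound 2 stands level with compound 1 rather than apart from it.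

Compound 3 `Clc1ncc(OC[C@@H]2CCN2)cc1-c1ccc(Br)nc1` is the next member of the series and has not yet been measured. Its change from compound 2 is bromo in place of chloro on an aromatic carbon, on an aromatic carbon of a six-membered aromatic ring with 1 nitrogen, next to the ring nitrogen and para to a large group. Among the measured compounds shown here, the one step that bears on it, the move from fluoro to chloro, stayed within the scatter, so a further move to bromo at the same place is expected to give no step beyond the scatter in this assay either.

Compound 3 is therefore estimated at 0.0045 nM, with a range from 0.0018 nM to 0.012 nM, which corresponds to an expected step of no change at the digits printed from compound 2 to compound 3 (within the scatter).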

Compound 3, inhibition constant: 0.0043 nM
Estimate against measurement, compound 3: 1.0-fold (0.02 log units) above; low and high end bracket the measured number.
By their numbers in this assay, from the lowest: compounds 3, 2 and 1 (each within the scatter of the next).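

In this assay, the move to bromo gives a 1.0-fold lower number from compound 2 to compound 3 (0.02 log units; within the scatter), and the wider swap across the series gives a 1.1-fold lower number from compound 1 to compound 3 (0.06 log units; within the scatter). Where the earlier pair showed only that fluoro and chloro could not be told apart, these steps extend this to three halogens on an aromatic carbon of a six-membered aromatic ring with 1 nitrogen, next to the ring nitrogen and para to a large group, and the comparison of fluoro with bromo also stays within the scatter. No other measurement accompanies these compounds that could say why the three stand level.

All three compounds carry a halogen at this place, so they cannot show whether the level holds only among halogens or extends to quite different groups, such as a methyl group, an amine, a nitrile or a carboxylic acid. Nor can they show whether iodo or a plain hydrogen at the same carbon would stand level with compound 3 in this assay.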